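Methoxy to methyl on a shared core: an estimate at the limit

The compounds below may be only part of what the source reports. "The series", "measured", "known", "first", "only" and "open" are said of these compounds alone.

compound 1 `C=C1C[C@]23C[C@@]1(O)CC[C@H]2c1ccc(O)c(C)c1[C@@H]3Cn1cc(-c2ccccn2)nn1` — in a functional assay on HL-60 cells (Homo sapiens) for cytotoxicity, read by MTT assay, with a stated time of 4 days (on this read-out higher numbers stand for weaker inhibition and lower numbers for stronger inhibition), compound 1 gives > 20000 nM, a limit of the assay.
compound 2 `C=C1C[C@]23C[C@@]1(O)CC[C@H]2c1ccc(O)c(C)c1[C@@H]3Cn1cc(-c2ccccc2)nn1` — in this assay compound 2 gives > 20000 nM, a limit of the assay.
compound 3 `C=C1C[C@]23C[C@@]1(O)CC[C@H]2c1ccc(O)c(C)c1[C@@H]3Cn1cc(-c2ccc(OC)cc2)nn1` — in this assay compound 3 gives > 20000 nM, a limit of the assay.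

Compound 3 thus stands at the limit of this assay, as the limit of > 20000 nM in this assay, at which 3 of the 3 values shown sit, records, and no number places it within the series. Compound 4 `C=C1C[C@]23C[C@@]1(O)CC[C@H]2c1ccc(O)c(C)c1[C@@H]3Cn1cc(-c2ccc(C)cc2)nn1` differs from compound 3 by methyl in place of methoxy on an aromatic carbon. The steps that might bear on this change carry no readable size: from compound 2 to compound 3, a step that the two limits leave unreadable from compound 2 to compound 3; from compound 1 to compound 2, a step that the two limits leave unreadable from compound 1 to compound 2; from compound 1 to compound 3, a step that the two limits leave unreadable from compound 1 to compound 3. None of them shows that a change on this aromatic carbon moves the value off the limit, so nothing in the series points to a step beyond the scatter. The expected step that the limit leaves unreadable from compound 3 to compound 4 is accordingly taken as none beyond the scatter. Compound 4 is therefore estimated at 30000 nM, within a range from 10000 nM to 100000 nM, and is expected most likely to be reported only as a limit.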

Compound 4, half-maximal inhibitory concentration: > 20000 nM
Compound 4 gave a limit, no number; the forecaster's own chance of this, stated with the estimate: 85%; the middle value is on the limit's open side.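

In this assay, among these compounds, compound 4 also gives only a limit, so no step from compound 1, compound 2 or compound 3 to compound 4 can be read: the limit of > 20000 nM in this assay, at which 4 of the 4 values shown sit. The compounds shown leave open which change on the shared core, if any, would bring a value off this limit.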